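The source may hold more compounds than are shown below. What is called first, only, known or untested is meant among the compounds shown, and "the series" means these compounds.

Compound 1 `O=C(/C=C/c1ccc(F)cc1)NS(=O)(=O)c1ccccc1` and compound 2 `Cc1ccc(S(=O)(=O)NC(=O)/C=C/c2ccc(F)cc2)cc1` share the same core and differ only by a methyl in place of hydrogen on an aromatic carbon. In a functional assay on B16-F10 cells (Mus musculus) for antiproliferative activity, read by ELISA and MTT assay, with a stated time of 48 h (a higher number here means a weaker inhibitor, a lower number a stronger inhibitor), compound 1 gives 2.1 ug/mL, and compound 2 gives 4.8 ug/mL, so that the change makes a 2.3-fold higher number from compound 1 to compound 2 (0.36 log units; beyond the scatter).

Compound 3 `O=C(/C=C/c1ccc(Br)cc1)NS(=O)(=O)c1ccccc1` stands against compound 1 with bromo in place of fluoro on an aromatic carbon. In this assay compound 3 gives 3.9 ug/mL, which is a 1.9-fold higher number from compound 1 to compound 3 (0.27 log units; within the scatter).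

Compound 4 `Cc1ccc(S(=O)(=O)NC(=O)/C=C/c2ccc(Br)cc2)cc1` is not yet measured. It differs from compound 3 by a methyl in place of hydrogen on an aromatic carbon, the same kind of change as that from compound 1 to compound 2; the two places are described in the same words, on an aromatic carbon of a six-membered aromatic ring of carbon only, para to a large group. For the measured compounds named here, only one measured example of this change exists, and it is of modest size, so the expectation rests on a single step.

For compound 4 in this assay the step is expected to be about a 2.1-fold higher number from compound 3 to compound 4 (0.31 log units; beyond the scatter), since the same change gave a 2.3-fold higher number from compound 1 to compound 2 (0.36 log units; beyond the scatter) and compound 3 starts from 3.9 ug/mL. Compound 4 is therefore estimated at 8 ug/mL, with a likely range from 4 ug/mL to 16 ug/mL.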

Compound 4, half-maximal inhibitory concentration: 12.1 ug/mL
Estimate against measurement, compound 4: 1.5-fold (0.18 log units) below; the range from low to high includes it.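

Compound 4 confirms that methyl in place of hydrogen on an aromatic carbon carries over to the bromo-bearing pair, where in this assay it gives a 3.1-fold higher number from compound 3 to compound 4 (0.49 log units; beyond the scatter), in the same direction as on the fluoro-bearing pair and with no difference in size that stands clear of the scatter: the same change on two cores in this assay, a 2.3-fold higher number (0.36 log units; beyond the scatter) from compound 1 to compound 2 and a 3.1-fold higher number (0.49 log units; beyond the scatter) from compound 3 to compound 4, 1.4-fold (0.13 log units) apart, within the scatter of two such steps

Bromo in place of fluoro, read on the methyl-bearing pair, gives a 2.5-fold higher number from compound 2 to compound 4 (0.40 log units; beyond the scatter), and this also agrees with the step on the pair without the methyl, although only the newer step lies beyond the scatter: the same change on two cores in this assay, a 1.9-fold higher number (0.27 log units; within the scatter) from compound 1 to compound 3 and a 2.5-fold higher number (0.40 log units; beyond the scatter) from compound 2 to compound 4, 1.4-fold (0.13 log units) apart, within the scatter of two such steps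

These steps show that, across these four compounds, each change moves the number the same way whichever form of the other position it meets, but they form a single closed set of pairs, so they do not show that either change would carry over to any other core or that the steps are exactly independent of each other.

The compounds shown leave open whether a methoxy, an amine or a carboxylic acid in place of the methyl would move the number in the same direction. They also leave open whether chloro or a nitrile in place of the bromo would fall in line with these steps.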